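From pyrimidin-4-yl to 2-fluoropyridin-3-yl on a shared core

The source may report more compounds than this note shows. Statements on the series, on what has been measured and on what is new or still open speak of the compounds shown alone.

Of the compounds shown here, two with a shared core have been measured in a physicochemical assay for solubility, measured as kinetic solubility, with a stated time of 1 h, at pH 7.4; on this read-out higher numbers stand for higher solubility and lower numbers for lower solubility. Compound 1 (`O=C(NC1=NN(c2ccc(Cl)c(Cl)c2)CC1)c1ccncc1`) gives 9000 nM, and compound 2 (`O=C(NC1=NN(c2ccc(Cl)c(Cl)c2)CC1)c1ccncn1`) gives 13000 nM. Among the measured compounds shown here, the one step between them is a 1.4-fold higher number from compound 1 to compound 2 (0.16 log units; within the scatter). For the measured compounds named here, on these numbers, compound 2 cannot be told apart from its only measured neighbour.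

Compound 3 (`O=C(NC1=NN(c2ccc(Cl)c(Cl)c2)CC1)c1cccnc1F`) has not yet been measured. It carries 2-fluoropyridin-3-yl in place of pyrimidin-4-yl on a carbonyl carbon. Going by the values given here, only one measured step bears on this change, the exchange at the same place that leads to compound 2, and it stayed within the scatter. It is weak guidance, since neither measured compound carries a fluorine and the data show nothing about this ring. No step beyond the scatter is therefore expected in this assay, with only a slight lean towards lower numbers. The expected step is a 1.6-fold lower number from compound 2 to compound 3 (0.21 log units; within the scatter). For compound 3 the estimated value is 8000 nM, with an expected range from 3000 nM to 16000 nM.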

Compound 3, solubility: 13000 nM
The estimate for compound 3 lay 1.6-fold (0.21 log units) below the measured number; low and high end bracket the measured number.
By their numbers in this assay, from the lowest: compounds 1, 2 and 3 (each within the scatter of the next).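

In this assay, the change on a carbonyl carbon whose other neighbours are an amide-type nitrogen now extends to a third ring, giving no change at the digits printed from compound 2 to compound 3 (within the scatter) and a 1.4-fold higher number from compound 1 to compound 3 (0.16 log units; within the scatter). The earlier pair compared only pyridin-4-yl with pyrimidin-4-yl, whereas 2-fluoropyridin-3-yl brings a fluorine to this place, and the three compounds still cannot be told apart on this read-out. Nothing on hand bears on why these three groups cannot be distinguished here.

From the compounds shown here alone, all three compounds carry a six-membered aromatic ring at this place, so it remains open whether an amine, a carboxylic acid or a longer chain on the same carbonyl carbon would give a step beyond the scatter in this assay. The compounds shown also all share one core, which leaves open whether these three groups would remain indistinguishable if the rest of the molecule were changed.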